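Compound 2 to compound 3: a diethylamino swap

The compounds below may be only part of what the source reports. "The series", "measured", "known", "first", "only" and "open" are said of these compounds alone.

Compound 1 `O=C1CSC(c2cccc(Br)c2)N1c1nccs1` gives > 50000 nM as a limit
Compound 2 `CCN(CC)C(=O)c1cccc(C2SCC(=O)N2c2ccccc2OC)c1` gives > 50000 nM as a limit

Both compounds were tested in a functional assay on MDA-MB-231 cells (Homo sapiens) for antiproliferative activity, read by sulforhodamine B assay, with a stated time of 48 h (on this read-out higher numbers stand for weaker inhibition and lower numbers for stronger inhibition), and neither returned a number. The whole record is the limit of > 50000 nM in this assay, at which 2 of the 2 values shown sit, and nothing more. Compound 3 `COc1ccccc1N1C(=O)CSC1c1cccc(C(=O)N2CCCCC2)c1` carries piperidin-1-yl in place of diethylamino on a carbonyl carbon, a change counted as piperidin-1-yl in place of diethylamino on a carbonyl carbon in full. Among the measured compounds shown here, no measured step guides this change. Compound 2 stands at > 50000 nM as a limit, so the expected step of a number no higher from compound 2 to compound 3 (the limit leaves the size open) is none beyond the scatter, in no set direction. Compound 3 is estimated at 50000 nM within an expected range of 15000 nM to 80000 nM in this assay once measured.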

Compound 3, half-maximal inhibitory concentration: > 50000 nM
Compound 3 was reported as a limit; the forecaster's own chance of this, stated with the estimate: 70%; the middle value lies on the limit itself.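

Compound 2 and compound 3 both stand as limits in this assay, so no step can be read between them: the limit of > 50000 nM in this assay, at which 3 of the 3 values shown sit. The compounds shown leave open whether piperidin-1-yl in place of diethylamino changes antiproliferative activity at all.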